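Triazole hydrazones: swapping the nitrophenyl end of compound 2

This account rests on a few compounds, and the source may have more. Where it says the series, first, only, none or still open, it means among the compounds named here.

Measured so far:
compound 1 `Fc1cccc(F)c1CSc1nnc(-c2ccncc2)n1-c1ccccc1` — 22100 nM
compound 2 `O=C(CSc1nnc(-c2ccncc2)n1-c1ccccc1)N/N=C/c1ccc([N+](=O)[O-])cc1` — 10200 nM

In a functional assay on HCT-116 cells (Homo sapiens) for inhibition, read by MTT assay, with a stated time of 48 h (a lower number here means a stronger inhibitor, a higher number a weaker inhibitor), compound 1 gives 22100 nM, and in this assay compound 2 gives 10200 nM. Compound 2 thus has the lower of the two numbers, and the gap to compound 1 lies beyond the usual scatter, so compound 2 is the stronger inhibitor of the pair.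

Compound 3 `O=C(CSc1nnc(-c2ccncc2)n1-c1ccccc1)N/N=C/C=C/c1ccccc1` is the next member. Relative to compound 2 the change is 2-phenylethenyl in place of 4-nitrophenyl on a carbon with a double bond to nitrogen. Among the measured compounds shown here, no pair of measured compounds separates this change on its own, so the expectation rests on compound 2 alone and on the fact that the 4-nitrophenyl group is exchanged for a group of similar size. Compound 3 is expected to remain close to compound 2, with a step of a 1.5-fold higher number from compound 2 to compound 3 (0.17 log units; within the scatter), small and not beyond the scatter, toward a slightly higher number. Compound 3 is estimated at 15000 nM, within 5000 nM to 45000 nM.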

Compound 3, half-maximal inhibitory concentration: 6150 nM
Compound 3: the middle estimate sits 2.4-fold (0.39 log units) above what was measured; the range from low to high includes it.
By their numbers in this assay, from the lowest: compounds 3 and 2 (each within the scatter of the next); then compound 1.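

At the carbon with a double bond to nitrogen, 2-phenylethenyl in place of 4-nitrophenyl gives, in this assay, a 1.7-fold lower number from compound 2 to compound 3 (0.22 log units; within the scatter), so this pair cannot be separated by this read-out. The change removes both hydrogen-bond acceptors of the leaving group and all of its nitrogen and oxygen, showing that, for this pair, this place does not need those atoms to keep the number within the scatter. No measurement here bears on the reason for this result.

Going by these compounds, it remains open whether a carbon-only aromatic ring is needed at this place at all, which a cyclohexyl group would test. Also open, on these data alone, is how an amine or a carboxylic acid on the phenyl ring, or a longer chain ending in phenyl, would read out in this assay.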